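A few compounds are considered here, and "the series" means these few. Any claim that something is new, unique, unknown or untested is made for them only; others in the source may bear on it.

Measured so far in an assay on isolated protein for inhibition of Amine oxidase [flavin-containing] B (Homo sapiens), read by fluorescence and Amplex Red, with a stated time of 15 min, tested at 50 uM; on this read-out higher numbers stand for more inhibition at the one concentration tested (going by the name of the read-out) and lower numbers for less inhibition:

- compound 1, `C#CCN(CCC)Cc1cn(-c2cc(NC(=S)NCC)ncn2)cn1`: in this assay compound 1 gives 24.3%
- compound 2, `C#CCN(Cc1cn(-c2cc(NC(=S)NCC)ncn2)cn1)C(C)=O`: in this assay compound 2 gives 1.17%

Compound 2 stands lowest of the two numbers recorded; its nearest neighbour is compound 1, whose number lies higher by more than the scatter. Among the compounds with values here, the single measured step runs a number 23.1 percentage points lower from compound 1 to compound 2 (beyond the scatter), the change being acetyl in place of propyl on an amine nitrogen.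

Compound 3, `C#CCN(Cc1ccccc1)Cc1cn(-c2cc(NC(=S)NCC)ncn2)cn1`, is not yet measured. It differs from compound 2 as follows:

benzyl in place of acetyl on an amine nitrogen

Within the data shown here, the only step that bears on this change is the one from compound 1 to compound 2, in which acetyl entering at the same amine nitrogen went with a drop beyond the scatter. Compound 3 removes that acetyl again and puts benzyl in its place, so the step is expected to run the other way, upward, and to be of roughly the same size as the drop seen before, that is a number 30.8 percentage points higher from compound 2 to compound 3 (beyond the scatter). The expected value for compound 3 in this assay is therefore estimated at 32%, with a range from 8% to 62%.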

Compound 3, a percentage reported as inhibition, at one concentration (the size of the read-out at that concentration, not a potency): 18.4%
The estimate for compound 3 lay 13.6 percentage points above the measured number; low and high end bracket the measured number.
By their numbers in this assay, from the lowest: compound 2; then compounds 3 and 1 (each within the scatter of the next).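

In this assay, benzyl in place of acetyl on the amine nitrogen gives a number 17.2 percentage points higher from compound 2 to compound 3 (beyond the scatter), so a number as low as that of compound 2 does not follow from every replacement of propyl at this nitrogen. Compared with the propyl compound, the benzyl compound shows a number 5.9 percentage points lower from compound 1 to compound 3 (within the scatter), so the saturated chain and the six-membered aromatic ring of benzyl cannot be told apart on this read-out, and among these compounds only the acetyl compound stands apart from the other two. No measured data on hand explain the separation of compound 2 from compound 1 and compound 3.

Still open, going by these compounds, is whether the separation belongs to acetyl alone or extends to other carbonyl-bearing groups, such as a methyl carbamate or a propanoyl group, and whether a plain methyl, a longer alkyl chain or a benzyl carrying a fluorine or a methoxy group would leave the number in the range of compound 1 and compound 3. These percentages at a single concentration also leave the potency of all three compounds open.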